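A quaternary ammonium series against collagen promoter activity

A few compounds are considered here, and "the series" means these few. Any claim that something is new, unique, unknown or untested is made for them only; others in the source may bear on it.

Three compounds of a shared core, each carrying a seven-carbon chain that ends in a charged nitrogen, were tested in an assay on LX2 cells for inhibition of COL1A1 promoter (Homo sapiens), read by a luciferase reporter, with a stated time of 24 h, tested at 20 uM; on this read-out lower numbers stand for a weaker effect and higher numbers for a stronger effect at the one concentration tested. Compound 1, `CN(C)c1ccc2c(=O)c(C(=O)Nc3cc(F)cc(F)c3)cn(-c3ccc(OCCCCCCC[N+]45CCN(CC4)CC5)cc3F)c2n1`, gives 9.02% in this assay. Compound 2, `CN(C)c1ccc2c(=O)c(C(=O)Nc3cc(F)cc(F)c3)cn(-c3ccc(OCCCCCCC[N+]4(C)CCCC4)cc3F)c2n1`, is reported in this assay as "not active" (no number reported). Compound 3, `CN(C)c1ccc2c(=O)c(C(=O)Nc3cc(F)cc(F)c3)cn(-c3ccc(OCCCCCCC[N+]4(C)CCCCC4)cc3Cl)c2n1`, is likewise reported in this assay as "not active" (no number reported), so no single number stands for it; it shares that outcome with compound 2, while compound 1 shows only a small effect. Nothing in these three compounds points to a strong effect anywhere in the set.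

Compound 4, `CN(C)c1ccc2c(=O)c(C(=O)Nc3cc(F)cc(F)c3)cn(-c3ccc(OCCCCCCC[N+]4(C)CCCCC4)cc3F)c2n1`, differs from compound 3 in one place: fluoro in place of chloro on an aromatic carbon, on an aromatic carbon of a six-membered aromatic ring of carbon only. For the measured compounds named here, no measured pair in this set isolates such a change, so no step size can be drawn from the data. Given that compound 3 is reported as "not active" (no number reported) and compound 2, with the same fluoro group, as "not active" (no number reported), no step beyond the usual scatter is expected in this assay. The inhibition for compound 4 in this assay is therefore estimated at 5%, within a range from -5% to 18%.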

Compound 4, a percentage reported as inhibition, at one concentration (the size of the read-out at that concentration, not a potency): "not active" (no number reported)
The entry for compound 4 holds no number; no gap can be computed for the estimate.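

In this assay compound 3 and compound 4 both stand without a number, so no step can be read for the change from chloro to fluoro. No evidence bears on this outcome. The compounds shown leave open whether exchanging chloro for fluoro at this place alters the inhibition at all.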